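Hydroxy placement on the aryl ring of the hydrazone

A few compounds are considered here, and "the series" means these few. Any claim that something is new, unique, unknown or untested is made for them only; others in the source may bear on it.

Measured compounds:
compound 1, `C/C(=N\NC(=O)c1cccc(S(=O)(=O)N2CCOCC2)c1)c1ccccc1O` — 1220 nM
compound 2, `C/C(=N\NC(=O)c1cccc(S(=O)(=O)N2CCOCC2)c1)c1cccc(O)c1` — > 100000 nM

In a functional assay on MGC-803 cells (Homo sapiens) for antiproliferative activity, read by MTT assay, with a stated time of 72 h (on this read-out lower numbers stand for stronger inhibition and higher numbers for weaker inhibition), compound 1 gives 1220 nM. Compound 2 reaches only a limit of this assay, > 100000 nM. Among the measured compounds shown here, the single measured step, an at least 81-fold higher number from compound 1 to compound 2 (1.91 log units; beyond the scatter), rests on that limit, (the limit of > 100000 nM in this assay, at which 1 of the 2 values shown sits), so its true size is not fixed. Compound 3, `C/C(=N\NC(=O)c1cccc(S(=O)(=O)N2CCOCC2)c1)c1cc(O)ccc1O`, differs from compound 2 by hydroxy in place of hydrogen on an aromatic carbon. The 2,5-dihydroxyphenyl of compound 3 carries within it the 2-hydroxyphenyl of compound 1, so the step from compound 1 to compound 2 bears on this change, read in the reverse direction. The number for compound 3 is therefore expected to drop well below that of compound 2, an at least 40-fold lower number from compound 2 to compound 3 (1.60 log units; beyond the scatter), back toward the region of compound 1. Compound 3 is estimated at 2500 nM, with a range from 500 nM to 40000 nM.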

Compound 3, half-maximal inhibitory concentration: 9090 nM
For compound 3 the middle estimate is 3.6-fold (0.56 log units) below the measured one; low and high end bracket the measured number.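

Hydroxy entering ortho to a large group and para to a hydroxy group restores a measurable value, with an at least 11-fold lower number from compound 2 to compound 3 (1.04 log units; beyond the scatter), so a second hydroxy can rescue the 3-hydroxyphenyl series at this position. The size of that step is not fixed, since it starts from a limit of this assay: the limit of > 100000 nM in this assay, at which 1 of the 3 values shown sits.

The extra hydroxy does not improve on the single hydroxy of the 2-hydroxyphenyl, which keeps the lower number, with a 7.5-fold higher number from compound 1 to compound 3 (0.87 log units; beyond the scatter), so the 2,5-dihydroxyphenyl recovers only part of what the 2-hydroxyphenyl gives.

The compounds shown leave open whether this position needs a hydroxy as such, or whether a methoxy, an amine or a fluorine in the same place would do the same. They also leave open how a single hydroxy at the 4-position of the phenyl would read.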